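The compounds below may be only part of what the source reports. "The series", "measured", "known", "first", "only" and "open" are said of these compounds alone.

Measured so far:
compound 1 `CS(=O)(=O)OC(c1ccccc1)c1cc2ccccc2o1` — in a functional assay on SW480 cells (Homo sapiens) for inhibition, read by MTT assay, with a stated time of 48 h (on this read-out lower numbers stand for stronger inhibition and higher numbers for weaker inhibition), compound 1 reaches only the limit > 40000 nM.
compound 2 `Cc1nccn1C(c1ccccc1)c1cc2ccccc2o1` — in this assay compound 2 likewise reaches only the limit > 40000 nM.

Compound 2 thus stands at the limit, where both values shown sit (the limit of > 40000 nM in this assay, at which 2 of the 2 values shown sit). The step that the two limits leave unreadable from compound 1 to compound 2, 2-methyl-1H-imidazol-1-yl in place of (methylsulfonyl)oxy on a saturated chain carbon bound to two aromatic carbons, is unreadable, both of its ends being limits. Compound 3 `CCc1nccn1C(c1ccccc1)c1cc2ccccc2o1` differs from compound 2 by methyl in place of hydrogen on a saturated chain carbon bound to an aromatic carbon, so that 2-methyl-1H-imidazol-1-yl becomes 2-ethyl-1H-imidazol-1-yl. No measured step bears on this change, and the one step shown gives no size. Compound 2 sits at the limit. Compound 3 is expected to stay at the limit as well, the step that the limit leaves unreadable from compound 2 to compound 3 being only nominal. The estimate for compound 3 in this assay is 60000 nM, within 20000 nM to 200000 nM.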

Compound 3, half-maximal inhibitory concentration: > 40000 nM
Compound 3: a limit, no number; the forecaster's own chance of this, stated with the estimate: 85%; the middle value lies beyond the limit too.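

In this assay compound 3 gives > 40000 nM, again a limit. No step among compound 1, compound 2 and compound 3 can be read, as all three share one limit: the limit of > 40000 nM in this assay, at which 3 of the 3 values shown sit.

The compounds shown leave open whether any change on the shared core gives a readable value.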